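Cytotoxicity of alkylamino pyrazine carboxamides on Vero cells

This account rests on a few compounds, and the source may have more. Where it says the series, first, only, none or still open, it means among the compounds named here.

Compound 1 `CCCCNc1cncc(C(=O)NCc2ccccc2)n1`: 100000 nM
Compound 2 `CCCCCCCCNc1cncc(C(=O)NCc2ccccc2)n1`: > 100000 nM
Compound 3 `O=C(NCc1ccccc1)c1cncc(Cl)n1`: "not determined" (no result reported)

In an ADME assay on Vero cells (Chlorocebus sabaeus) for cytotoxicity, read by microscopy, with a stated time of 6 days (a lower number here means that less compound is tolerated, a higher number that more compound is tolerated), compound 1 gives 100000 nM. For compound 2 the assay reports only a limit, > 100000 nM, which is the limit of > 100000 nM in this assay, at which 1 of the 3 values shown sits. The step of a number no lower from compound 1 to compound 2 (the limit leaves the size open) therefore cannot be sized. Compound 3 `O=C(NCc1ccccc1)c1cncc(Cl)n1` gives "not determined" (no result reported) in this assay, so it stands outside the measured range altogether.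

Compound 4 `CCCCCNc1cncc(C(=O)NCc2ccccc2)n1` differs from compound 3 by pentylamino in place of chloro on an aromatic carbon. Within the data shown here, no measured step covers this change, since compound 3 has no value and the only measured step concerns a longer chain on a compound that already carries an alkylamino group. The chain of compound 4 lies between those of compound 1 and compound 2, whose values in this assay are the number and the limit just given. Compound 4 is therefore expected to tolerate a similar concentration, estimated at 100000 nM with a range from 50000 nM to 200000 nM, and a limit rather than a number is a real possibility.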

Compound 4, minimum cytotoxic concentration: > 100000 nM
Compound 4: a limit, no number (the forecaster's own chance of this, stated with the estimate: 50%); the middle value lies on the limit itself.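

In this assay, one methyl added to the butyl chain of compound 1 gives a number no lower from compound 1 to compound 4 (the limit leaves the size open), so the second chain length to reach the limit is only one carbon longer than the butyl chain. Compound 4 reports only a limit, the same one as compound 2: the limit of > 100000 nM in this assay, at which 2 of the 4 values shown sit. The steps from compound 2 to compound 4 and from compound 3 to compound 4 cannot be read, so pentylamino and the octyl chain of compound 2 cannot be told apart here, and the change from chloro to pentylamino has no size.

On these data alone, only compound 1 gives a number, so it remains open how a shorter chain such as ethylamino would read. The compounds shown also leave open where an unsubstituted amine or a carboxylic acid on that aromatic carbon would stand.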